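Swapping Trifluoromethyl for Methyl: What to Expect

This account rests on a few compounds, and the source may have more. Where it says the series, first, only, none or still open, it means among the compounds named here.

Measured so far:
- Compound 1, `COC(=O)c1cn([C@@H]2c3cc(C#N)ccc3OC(C)(C)[C@H]2O)c2ccccc12`: 500 nM
- Compound 2, `CC1(C)Oc2ccc(C#N)cc2[C@@H](/N=C(\NC#N)Nc2cccc(C(F)(F)F)c2)[C@@H]1O`: 1600 nM

Both compounds were tested in a functional assay (aorta) with Rattus norvegicus as the target; on this read-out lower numbers stand for stronger inhibition and higher numbers for weaker inhibition. Compound 1 gives 500 nM there, and compound 2 gives 1600 nM, the higher of the two numbers. The gap between them is beyond the usual scatter, so compound 2 is the weaker inhibitor of the pair, though the two share only part of their structure and no single-point comparison links them.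

Compound 3, `Cc1cccc(N/C(=N/[C@@H]2c3cc(C#N)ccc3OC(C)(C)[C@H]2O)NC#N)c1`, has not yet been measured. It keeps the whole of compound 2 except at one spot: methyl in place of trifluoromethyl on an aromatic carbon. Among the measured compounds shown here, no measured pair shows what this change does, so the expectation rests on compound 2 alone, whose value of 1600 nM is the anchor. The step from compound 2 to compound 3 is estimated as a 1.1-fold lower number from compound 2 to compound 3 (0.03 log units; within the scatter), that is, no change beyond the scatter in either direction. Compound 3 is therefore expected to give about 1500 nM, within a range of 500 nM to 4500 nM.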

Compound 3, half-maximal inhibitory concentration: 1000 nM
Compound 3: middle estimate off by 1.5-fold (0.18 log units), on the high side; the range from low to high includes it.
By their numbers in this assay, from the lowest: compounds 1, 3 and 2 (each within the scatter of the next, the first and the last beyond it).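

In this assay methyl in place of trifluoromethyl on this aromatic carbon gives a 1.6-fold lower number from compound 2 to compound 3 (0.20 log units; within the scatter) and so no change that can be told apart from the scatter. Among the compounds shown here, this is the first comparison that isolates a single position, since compound 1 and compound 2 differ in more than one place, and it shows that this read-out does not separate the 3-(trifluoromethyl)phenyl and 3-methylphenyl forms. Nothing measured here speaks to the reason for this result.

On these data alone, neither group has a ring or any hydrogen-bond donor or acceptor, so it remains open whether an amine, a carboxylic acid or a longer chain on the same carbon would move the number beyond the scatter. As far as these compounds go, whether the same swap would behave alike elsewhere on the ring is also open.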